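A few compounds are considered here, and "the series" means these few. Any claim that something is new, unique, unknown or untested is made for them only; others in the source may bear on it.

Measured compounds:
- compound 1, `N#CCC(=O)N/N=C1\C(=O)Nc2ccc(S(=O)(=O)N3CCOCC3)cc21`: 27700 nM
- compound 2, `N=c1oc2ccccc2cc1C(=O)N/N=C1\C(=O)Nc2ccc(S(=O)(=O)N3CCOCC3)cc21`: 20800 nM
- compound 3, `O=C1Nc2ccc(S(=O)(=O)N3CCOCC3)cc2/C1=N/c1ccc(O)cc1`: 52700 nM

All three share one core and were tested in a functional assay on MCF7 cells (Homo sapiens) for cytotoxicity, read by sulforhodamine B assay, with a stated time of 24 h; a higher number here means a weaker inhibitor, a lower number a stronger inhibitor. Compound 3 stands at the top of the three numbers shown: its gap to compound 1 is given by a 1.9-fold higher number from compound 1 to compound 3 (0.28 log units; within the scatter), while against compound 2 the two values sit further apart than the scatter allows.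

Compound 4, `CC(=O)c1cccc(/N=C2\C(=O)Nc3ccc(S(=O)(=O)N4CCOCC4)cc32)c1`, has not yet been measured. It differs from compound 3 in this way: 3-acetylphenyl in place of 4-hydroxyphenyl on a double-bonded nitrogen.

Among the measured compounds shown here, none of the measured steps swaps one aryl group for another on that double-bonded nitrogen. The step of a 1.9-fold higher number from compound 1 to compound 3 (0.28 log units; within the scatter) touches the same position but exchanges a chain for an aryl group, and it stayed within the scatter; the step of a 1.3-fold lower number from compound 1 to compound 2 (0.12 log units; within the scatter), at a different position, also stayed within the scatter. So the numbers give no precedent for a large shift. Compound 4 is therefore expected to land near compound 3, with a step of a 1.1-fold lower number from compound 3 to compound 4 (0.02 log units; within the scatter) that is not expected to exceed the scatter. For compound 4 in this assay the estimate is 50000 nM, within a range of 20000 nM to 125000 nM.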

Compound 4, half-maximal inhibitory concentration: 39200 nM
Estimate against measurement, compound 4: 1.3-fold (0.11 log units) above; low and high end bracket the measured number.
By their numbers in this assay, from the lowest: compounds 2, 1, 4 and 3 (each within the scatter of the next, the first and the last beyond it).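

In this assay the exchange of one aryl group for another on the double-bonded nitrogen can now be read directly: 3-acetylphenyl in place of 4-hydroxyphenyl gives a 1.3-fold lower number from compound 3 to compound 4 (0.13 log units; within the scatter) and so stays within the scatter, even though the hydroxyl-bearing group's hydrogen-bond donor is absent from the group that enters and the substituent's name carries a different ring number. The chain-to-aryl exchange now has a second example, a 1.4-fold higher number from compound 1 to compound 4 (0.15 log units; within the scatter), which, like a 1.9-fold higher number from compound 1 to compound 3 (0.28 log units; within the scatter), is within the scatter, so compounds 1, 3 and 4 cannot be told apart in this assay despite the different groups on that nitrogen. The data shown offer no measurement that would account for how little these exchanges register.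

The compounds shown leave open whether the acetyl and hydroxyl groups matter at all on their own, since 3-hydroxyphenyl and 4-acetylphenyl would be needed to separate the identity of the group from its place on the ring. They also leave open whether an aminophenyl group, a carboxyphenyl group or a longer alkyl chain on that nitrogen would produce a step beyond the scatter.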